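An Amine Replaces the Acid on the Side Chain

This account rests on a few compounds, and the source may have more. Where it says the series, first, only, none or still open, it means among the compounds named here.

Compound 1, `O=P(O)(O)OCc1nc(Nc2ccc(C(F)(F)F)cc2)c2ccc(-c3ncccc3C(F)(F)F)cc2n1`, gives 46 nM in a functional assay for antagonist activity at transient receptor potential cation channel subfamily V member 1 (Homo sapiens); a lower number here means a stronger inhibitor, a higher number a weaker inhibitor.
Compound 2, `OCCc1nc(Nc2ccc(C(F)(F)F)cc2)c2ccc(-c3ncccc3C(F)(F)F)cc2n1`, gives 22 nM in this assay.
Compound 3, `O=C(O)CCc1nc(Nc2ccc(C(F)(F)F)cc2)c2ccc(-c3ncccc3C(F)(F)F)cc2n1`, gives 1630 nM in this assay.

Among these three, compound 3 stands highest: its number lies a 35-fold higher number from compound 1 to compound 3 (1.55 log units; beyond the scatter) and a 74-fold higher number from compound 2 to compound 3 (1.87 log units; beyond the scatter), both steps well beyond the scatter. Compound 4, `CC(C)NCc1nc(Nc2ccc(C(F)(F)F)cc2)c2ccc(-c3ncccc3C(F)(F)F)cc2n1`, has not yet been measured in this assay. It differs from compound 3 in one place: isopropylamino in place of carboxymethyl on a saturated chain carbon bound to an aromatic carbon.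

For the measured compounds named here, two measured steps bear on this change. The step of a 74-fold higher number from compound 2 to compound 3 (1.87 log units; beyond the scatter) and the step of a 35-fold higher number from compound 1 to compound 3 (1.55 log units; beyond the scatter) both show that compound 3, the only one bearing carboxy, gives a far higher number than either neighbour carrying hydroxy or the phosphorus-containing group on the chain. The step of a 2.1-fold lower number from compound 1 to compound 2 (0.32 log units; beyond the scatter) is modest by comparison. Going by the values given here, compound 4 no longer carries the carboxy group, so a large downward step is expected, of a size comparable to those two steps, though the isopropylamino group itself has no precedent here. The estimated step is a 33-fold lower number from compound 3 to compound 4 (1.51 log units; beyond the scatter). Compound 4 is therefore expected to give about 50 nM in this assay, with a plausible range from 10 nM to 300 nM.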

Compound 4, half-maximal inhibitory concentration: 35 nM
The estimate for compound 4 lay 1.4-fold (0.15 log units) above the measured number; the range from low to high includes it.
By their numbers in this assay, from the lowest: compounds 2, 4 and 1 (each within the scatter of the next, the first and the last beyond it); then compound 3.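

The step of a 47-fold lower number from compound 3 to compound 4 (1.67 log units; beyond the scatter) in this assay shows that the high number of compound 3 does not carry over to every group of this size on the saturated chain carbon: carboxymethyl and isopropylamino match in heavy atoms, hydrogen-bond donors and hydrogen-bond acceptors as counted, yet the numbers lie far apart. The step of a 1.6-fold higher number from compound 2 to compound 4 (0.20 log units; within the scatter) and the step of a 1.3-fold lower number from compound 1 to compound 4 (0.12 log units; within the scatter) both lie within the scatter, so compound 4 cannot be set apart from either neighbour. Among the four compounds, the amine, the hydroxy compound and the phosphorus-containing compound all stay in one low region, and compound 3, the only one with a carboxylic acid, is the exception.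

Nothing shown here gives a measured reason for the gap between the acid and the other three groups. Still open, as far as these compounds go, is whether the high number belongs to the free acid alone, which a methyl ester or a primary amide on the same chain would test, and whether a smaller amine such as methylamino or a ring amine such as morpholine would match the isopropylamino group.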